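The compounds below may be only part of what the source reports. "The series", "measured", "known", "first", "only" and "open" are said of these compounds alone.

Of the compounds shown here, three built on one shared core have so far been tested in a functional assay on HEK293 cells with D(4) dopamine receptor (Homo sapiens) as the target, read by FLIPR; on this read-out higher numbers stand for an effect only at larger amounts of compound and lower numbers for an effect already at smaller amounts. Compound 1 `O/N=C(/CCN1CCN(c2ccccn2)CC1)c1ccccc1` gives 21.7 nM. Compound 2 `Cc1ccccc1/C(CCN1CCN(c2ccccn2)CC1)=N\O` gives 20.3 nM, and the step of a 1.1-fold lower number from compound 1 to compound 2 (0.03 log units; within the scatter) goes with a methyl in place of hydrogen on an aromatic carbon. Compound 3 `O/N=C(\CCN1CCN(c2ccccn2)CC1)c1cccc(F)c1` gives 17.1 nM, the lowest of the three numbers, yet its distance to compound 2 and to compound 1 lies within the scatter, so the three values cannot be told apart. Compound 1 and compound 3 differ by a single fluorine atom, and their two values show no separation beyond the scatter either.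

Compound 4 `O/N=C(\CCN1CCN(c2ccccn2)CC1)c1ccc(Cl)cc1` has not yet been measured. Its difference from compound 3 is 4-chlorophenyl in place of 3-fluorophenyl on a carbon with a double bond to nitrogen. Among the compounds with values here, the only measured step that bears on such a change at the aromatic ring is a 1.1-fold lower number from compound 1 to compound 2 (0.03 log units; within the scatter), which left the number essentially where it was, and the pair of compound 1 and compound 3 likewise shows two values within the scatter. Because a 1.1-fold lower number from compound 1 to compound 2 (0.03 log units; within the scatter) stayed within the scatter, compound 4 is expected to remain close to compound 3, with a step of a 1.1-fold higher number from compound 3 to compound 4 (0.02 log units; within the scatter) that is not expected to exceed the scatter. The estimate for compound 4 in this assay is 18 nM, with a range from 8 nM to 45 nM.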

Compound 4, half-maximal effective concentration: 475 nM
Beside the measured number, compound 4's estimate is 26-fold (1.42 log units) below it, outside the stated range (above it).
By their numbers in this assay, from the lowest: compounds 3, 2 and 1 (each within the scatter of the next); then compound 4.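

In this assay, within the data shown here, the step of a 28-fold higher number from compound 3 to compound 4 (1.44 log units; beyond the scatter) is large and beyond the scatter, so the aromatic group on the carbon with a double bond to nitrogen is not as free to change as the earlier compounds suggested, where the step of a 1.1-fold lower number from compound 1 to compound 2 (0.03 log units; within the scatter) stayed within the scatter. The simple counts do not separate the two groups: 3-fluorophenyl and 4-chlorophenyl each have 7 heavy atoms, one six-membered aromatic ring of carbon only, no hydrogen-bond donors or acceptors and no net charge, so the large step goes with a change in which halogen is present and where it stands on the ring. Nothing shown here gives a measured reason for this step.

Both the halogen and its place on the ring differ at once between these two compounds, so the data cannot say which of the two changes goes with the large step. On these data alone, whether a bromine or a methoxy group in place of the chlorine of the 4-chlorophenyl group would give a number close to that of compound 4 also stays open.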